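Replacing the acetyl of compound 2 with an ethyl group

The source may hold more compounds than are shown below. What is called first, only, known or untested is meant among the compounds shown, and "the series" means these compounds.

Three compounds share one core. Compound 1 `Cc1nc2c(OCc3ccccc3)cccn2c1N` carries a free amine and in a functional assay on the whole organism with Canis familiaris (Canis lupus familiaris) as the target, at a dose of 2 mg/kg by the intravenous route (on this read-out lower numbers stand for a weaker effect and higher numbers for a stronger effect at the one dose given), compound 1 gives 97%. Compound 2 `CC(=O)Nc1c(C)nc2c(OCc3ccccc3)cccn12` is its acetamide and in this assay compound 2 gives 24%, the lowest of the three numbers. Compound 3 `Cc1nc2c(OCc3ccccc3)cccn2c1NC(=O)OCc1ccccc1` bears a benzyl carbamate instead and in this assay compound 3 gives 82%. Two steps frame compound 2: a number 73 percentage points lower from compound 1 to compound 2 (beyond the scatter), and a number 58 percentage points higher from compound 2 to compound 3 (beyond the scatter), both large.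

Compound 4 `CCNc1c(C)nc2c(OCc3ccccc3)cccn12` is the next candidate. Its difference from compound 2 is ethyl in place of acetyl on a nitrogen on an aromatic ring. The carbonyl is gone, so compound 4 stands nearer in kind to compound 1 than to compound 2. Both measured steps show that the acetyl of compound 2 is tied to its low number, so a large upward step in this assay is expected. For compound 4 in this assay a value of 75% is estimated, with a range of 40% to 97%. This estimate means an expected step of a number 51 percentage points higher from compound 2 to compound 4 (beyond the scatter).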

Compound 4, a percentage reported as inhibition, in the whole organism at one dose (the size of the read-out at that dose, not a potency): 32%
Beside the measured number, compound 4's estimate is 43 percentage points above it; measured number below the stated range.
By their numbers in this assay, from the lowest: compounds 2 and 4 (each within the scatter of the next); then compound 3; then compound 1.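

Taking away the carbonyl does little at this nitrogen: in this assay there is a number 8 percentage points higher from compound 2 to compound 4 (within the scatter), so the acetyl carbonyl alone does not separate compound 2 from compound 1. The ethylamino group, with no carbonyl, still comes with a number 65 percentage points lower from compound 1 to compound 4 (beyond the scatter), which means that in compounds 2 and 4 both kinds of group on this nitrogen go with a large loss, while compound 3, at 82%, goes against that pattern. No measurement offered here explains these differences.

The compounds shown leave open whether a methyl group or a longer chain such as propyl on this nitrogen would read like ethyl. They also leave open whether a methyl carbamate would keep the high number of the benzyl carbamate of compound 3.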